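Replacing the pyridin-2-yl ring in an imidazoline series

This account rests on a few compounds, and the source may have more. Where it says the series, first, only, none or still open, it means among the compounds named here.

Compound 1 `Cc1ccccc1-c1ccccc1OC(C)C1=NCCN1`: 234 nM
Compound 2 `Cc1cccc(-c2ccccc2OC(C)C2=NCCN2)c1`: 245 nM
Compound 3 `CC(Oc1ccccc1-c1ccccn1)C1=NCCN1`: 1260 nM

In an assay on CHO cells for displacement of a labelled ligand from Alpha-2C adrenergic receptor (Homo sapiens) (a higher number here means a weaker inhibitor, a lower number a stronger inhibitor), compound 3 stands highest of the three measured compounds. Compound 1 and compound 2 lie lower, as the steps of a 5.4-fold higher number from compound 1 to compound 3 (0.73 log units; beyond the scatter) and a 5.1-fold higher number from compound 2 to compound 3 (0.71 log units; beyond the scatter) show, while the step of a 1.0-fold higher number from compound 1 to compound 2 (0.02 log units; within the scatter) lies within the scatter. Compound 4 `CC(Oc1ccccc1-c1ccc(O)cc1)C1=NCCN1` has not been measured; it differs from compound 3 by 4-hydroxyphenyl in place of pyridin-2-yl on an aromatic carbon. Both steps that bear on this change moved from a carbon-only ring to pyridin-2-yl and raised the number by a modest amount; the present change runs the other way, back to a carbon-only ring, though to 4-hydroxyphenyl rather than a methylphenyl. A modest downward step in this assay is therefore expected. Compound 4 is estimated at 350 nM, within 120 nM to 1000 nM, an expected step of a 3.6-fold lower number from compound 3 to compound 4 (0.56 log units; beyond the scatter).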

Compound 4, inhibition constant: 331 nM
Compound 4: middle estimate off by 1.1-fold (0.02 log units), on the high side; measured number inside the range.
By their numbers in this assay, from the lowest: compounds 1, 2 and 4 (each within the scatter of the next); then compound 3.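

In this assay, 4-hydroxyphenyl also gives a lower number than pyridin-2-yl (a 3.8-fold lower number from compound 3 to compound 4 (0.58 log units; beyond the scatter)), so the gap to pyridin-2-yl is not limited to the two methylphenyl rings. Compound 4 cannot be separated from either methylphenyl compound (a 1.4-fold higher number from compound 2 to compound 4 (0.13 log units; within the scatter); a 1.4-fold higher number from compound 1 to compound 4 (0.15 log units; within the scatter)), so at this position these three carbon-only rings read alike, whether they carry methyl or hydroxyl. Nothing available explains the gap between them and pyridin-2-yl. The compounds shown leave open whether a methoxy group or an amine in place of the hydroxyl of compound 4 would keep the number in the same range.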